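The compounds below may be only part of what the source reports. "The series", "measured", "known", "first", "only" and "open" are said of these compounds alone.

Compound 1, whose structure is `CCn1cc(-c2cccc(F)c2)c(=O)c2cc(F)c(N3CCNCC3)cc21`, was examined in a functional assay on HepG2 cells (Homo sapiens) for antiproliferative activity, read by MTT assay, with a stated time of 48 h (on this read-out higher numbers stand for weaker inhibition and lower numbers for stronger inhibition), where compound 1 gives 27800 nM. Compound 2, `CCn1cc(-c2cccc(Cl)c2)c(=O)c2cc(F)c(N3CCNCC3)cc21`, carries chloro in place of fluoro on an aromatic carbon relative to compound 1, and in this assay compound 2 gives 15300 nM. The resulting step, a 1.8-fold lower number from compound 1 to compound 2 (0.26 log units; within the scatter), is small and sits within the scatter of repeated measurements, so the two numbers cannot be ranked against each other.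

Compound 3, `O=c1c(-c2ccc(F)cc2)cn(C2CC2)c2cc(N3CCNCC3)c(F)cc12`, rests on a different core; the difference between the two cores is not broken down here. In this assay compound 3 gives 10600 nM.

Compound 4, `O=c1c(-c2ccc(Cl)cc2)cn(C2CC2)c2cc(N3CCNCC3)c(F)cc12`, has not yet been measured. It stands to compound 3 as compound 2 stands to compound 1: chloro in place of fluoro on an aromatic carbon. The surroundings are not identical, however. In the earlier pair the changed carbon is meta to a large group, whereas in compound 3 and compound 4 it is para to a large group, so the change is the same kind of change rather than the same one.

Going by the values given here, the only guide to the size of the step is the earlier pair, and because a 1.8-fold lower number from compound 1 to compound 2 (0.26 log units; within the scatter) stayed within the scatter, the step from compound 3 to compound 4 is expected to be of similar modest size, a 1.5-fold lower number from compound 3 to compound 4 (0.18 log units; within the scatter). On that basis compound 4 is estimated to give 7000 nM in this assay, with a plausible range from 3500 nM to 14000 nM.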

Compound 4, half-maximal inhibitory concentration: 8020 nM
Compound 4: middle estimate off by 1.1-fold (0.06 log units), on the low side; measured number inside the range.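

On the core of compound 3, chloro in place of fluoro on an aromatic carbon, here the change from 4-fluorophenyl to 4-chlorophenyl, gives a 1.3-fold lower number from compound 3 to compound 4 (0.12 log units; within the scatter) in this assay, so this pair, like the earlier one, cannot be ranked. Set side by side, the two steps do not differ, and on these two cores the change behaves alike, with neither step standing out from the other: the same change on two cores in this assay, a 1.8-fold lower number (0.26 log units; within the scatter) from compound 1 to compound 2 and a 1.3-fold lower number (0.12 log units; within the scatter) from compound 3 to compound 4, 1.4-fold (0.14 log units) apart, within the scatter of two such steps

This does not show that the change has a real effect on either core, since each step on its own stays within the scatter, and two pairs are too few to establish a rule for the series; the pairs also differ in where the change sits as well as in their cores, and these two differences cannot be separated here.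

The compounds shown leave open whether a group other than the two halogens on that carbon, such as bromo, methoxy or nitrile, would give a step beyond the scatter. They also leave open whether the change from fluoro to chloro would stay as small on a core carrying a longer chain or a carboxylic acid.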